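The source may hold more compounds than are shown below. What is called first, only, known or untested is meant among the compounds shown, and "the series" means these compounds.

Measured so far:
- compound 1 `O=C(/C=C/c1ccccc1Br)NNC(=O)c1ccc2c(c1)OCCO2`: 2110 nM
- compound 2 `O=C(/C=C/c1cccc([N+](=O)[O-])c1)NNC(=O)c1ccc2c(c1)OCCO2`: 1560 nM
- compound 3 `O=C(/C=C/c1ccccc1)NNC(=O)c1ccc2c(c1)OCCO2`: 550 nM

All three share the same core, and all were tested in a functional assay on cells (Cancer cell lines, Homo sapiens) for inhibition, read by MTT assay, with a stated time of 48 h; on this read-out lower numbers stand for stronger inhibition and higher numbers for weaker inhibition. Compound 1 gives the highest number of the three; compound 2 sits close, since a 1.4-fold lower number from compound 1 to compound 2 (0.13 log units; within the scatter), while compound 3 lies clearly apart, since a 3.8-fold lower number from compound 1 to compound 3 (0.58 log units; beyond the scatter). The step from compound 2 to compound 3 points the same way, as a 2.8-fold lower number from compound 2 to compound 3 (0.45 log units; beyond the scatter).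

Compound 4 `O=C(/C=C/c1cccc(F)c1)NNC(=O)c1ccc2c(c1)OCCO2` is not yet measured. Compared with compound 1, the change is 3-fluorophenyl in place of 2-bromophenyl on a double-bonded chain carbon bound to a double-bonded chain carbon. Within the data shown here, two measured steps bear on it: removing bromo, a 3.8-fold lower number from compound 1 to compound 3 (0.58 log units; beyond the scatter), and removing nitro, a 2.8-fold lower number from compound 2 to compound 3 (0.45 log units; beyond the scatter), both lower the number by a modest margin, whereas swapping one substituted phenyl for another, a 1.4-fold lower number from compound 1 to compound 2 (0.13 log units; within the scatter), stays within the scatter. Among the measured compounds shown here, a fluorine-bearing phenyl has no direct precedent here, so compound 4 is expected to fall between compound 1 and compound 3, with an estimated step of a 2.2-fold lower number from compound 1 to compound 4 (0.35 log units; beyond the scatter). The estimate for compound 4 in this assay is 950 nM, within a range from 400 nM to 2300 nM.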

Compound 4, half-maximal inhibitory concentration: 4110 nM
Beside the measured number, compound 4's estimate is 4.3-fold (0.64 log units) below it; the measured number lies above the stated range.
By their numbers in this assay, from the lowest: compound 3; then compounds 2, 1 and 4 (each within the scatter of the next, the first and the last beyond it).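

In this assay, a fluoro group on the phenyl ring also gives a higher number than the plain phenyl ring (a 7.5-fold higher number from compound 3 to compound 4 (0.87 log units; beyond the scatter)), so bromo, nitro and fluoro all go the same way and no compound shown goes against this. The substituent's identity also matters when the ring name keeps the same number, since fluoro in place of nitro gives a clear step (a 2.6-fold higher number from compound 2 to compound 4 (0.42 log units; beyond the scatter)). Compound 1 and compound 4 cannot be told apart (a 1.9-fold higher number from compound 1 to compound 4 (0.29 log units; within the scatter)), even though both the group and its printed ring number differ.

Nothing measured here explains why these groups on the phenyl ring give higher numbers. On these data alone, it remains open whether a methoxy group or an amine on this ring would also give a higher number than compound 3.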